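The compounds below may be only part of what the source reports. "The series", "measured", "known", "first", "only" and "open" are said of these compounds alone.

Measured in an ADME assay on THP-1 cells (Homo sapiens) for cytotoxicity, read by flow cytometry and propidium iodide staining, with a stated time of 72 h; on this read-out lower numbers stand for stronger inhibition and higher numbers for weaker inhibition:
- compound 1 `Nc1ccc2oc(-c3ccccc3F)cc(=O)c2c1`: 44000 nM
- compound 2 `COc1c(-c2ccccc2)oc2ccc(N)cc2c1=O`: 74000 nM
- compound 3 `COc1ccccc1-c1oc2ccc(N)cc2c(=O)c1OC`: 116000 nM

Compound 3 stands within the scatter of compound 2, while compound 1 has a number lower than compound 3 by more than the scatter. Compound 4 `COc1c(-c2ccccc2F)oc2ccc(N)cc2c1=O` has fluoro in place of methoxy on an aromatic carbon, ortho to a large group: fluoro in place of methoxy on an aromatic carbon. No such exchange has been measured. The measured step bearing on it is a 1.6-fold higher number from compound 2 to compound 3 (0.20 log units; within the scatter), with methoxy in place of hydrogen, so no step beyond the scatter is expected in this assay. Compound 1 carries the same fluoro without any methoxy and gives 44000 nM. The expected change is a 1.5-fold lower number from compound 3 to compound 4 (0.19 log units; within the scatter). For compound 4 the estimate is 75000 nM, with an expected range of 38000 nM to 135000 nM.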

Compound 4, half-maximal inhibitory concentration: > 125000 nM
Compound 4: only a limit was reported; the forecaster's own chance of this, stated with the estimate: 10%; middle value at least 1.6-fold (0.22 log units) from the limit.
By their numbers in this assay, from the lowest: compounds 1, 2 and 3 (each within the scatter of the next, the first and the last beyond it). At a limit, above all of these: compound 4.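

In this assay compound 4 gives only a limit, > 125000 nM. On an aromatic carbon ortho to a large group, fluoro in place of methoxy gives an at least 1.0-fold higher number from compound 3 to compound 4 (0.03 log units; that floor lies within the scatter), and fluoro in place of hydrogen gives an at least 1.6-fold higher number from compound 2 to compound 4 (0.22 log units; that floor lies within the scatter), so the true size of neither step is settled. Methoxy in place of hydrogen now gives a step whose floor passes the scatter, an at least 2.8-fold higher number from compound 1 to compound 4 (0.45 log units; beyond the scatter), on a second core: the same change on two cores in this assay, a 1.6-fold higher number (0.20 log units; within the scatter) from compound 2 to compound 3 and an at least 2.8-fold higher number (0.45 log units; beyond the scatter) from compound 1 to compound 4; the limit leaves it open whether they differ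

The compounds shown leave open how a chloro or a hydroxyl group on this aromatic carbon would read in this assay.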